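Trifluoromethyl for methyl on the anilide of compound 1

This account rests on a few compounds, and the source may have more. Where it says the series, first, only, none or still open, it means among the compounds named here.

Compound 1 `COc1ccc(C(=O)Nc2ccccc2C)cc1OC1CCCC1` gives 300 nM in an assay on isolated protein for inhibition of phosphodiesterase 4A (Sus scrofa); a lower number here means a stronger inhibitor, a higher number a weaker inhibitor.
Compound 2 `COc1ccc(C(=O)Nc2c(F)cccc2F)cc1OC1CCCC1` gives 70 nM in this assay.
Compound 3 `COc1ccc(C(=O)Nc2c(C)cccc2Cl)cc1OC1CCCC1` gives 100 nM in this assay.

Compound 1 has the highest number of the three in this assay. Compound 4 `COc1ccc(C(=O)Nc2ccccc2C(F)(F)F)cc1OC1CCCC1` differs from it by trifluoromethyl in place of methyl on an aromatic carbon. Among the measured compounds shown here, two measured steps bear on this: a 4.3-fold lower number from compound 1 to compound 2 (0.63 log units; beyond the scatter) and a 3.0-fold lower number from compound 1 to compound 3 (0.48 log units; beyond the scatter), both bringing fluorine or chloro onto the ring of the amide-type nitrogen and both lowering the number beyond the scatter, though neither places trifluoromethyl. A modest drop for compound 4 in this assay is therefore expected, roughly a 1.8-fold lower number from compound 1 to compound 4 (0.25 log units; within the scatter). The estimate for compound 4 is 170 nM, with a range from 60 nM to 500 nM.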

Compound 4, half-maximal inhibitory concentration: 3100 nM
The estimate for compound 4 lay 18-fold (1.26 log units) below the measured number; measured number outside the range, above it.
By their numbers in this assay, from the lowest: compounds 2 and 3 (each within the scatter of the next); then compound 1; then compound 4.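

In this assay, trifluoromethyl in place of methyl gives a 10-fold higher number from compound 1 to compound 4 (1.01 log units; beyond the scatter), so this place on the ring is sensitive to which group it carries. The earlier steps on this ring all lowered the number, so this is the first shown to raise it, and a group carrying fluorine does not by itself bring a lower number here. Nothing measured here explains the rise.

Still open, on these data alone, is how a single chloro, methoxy or amine at this same place would compare with the methyl of compound 1.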